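This account rests on a few compounds, and the source may have more. Where it says the series, first, only, none or still open, it means among the compounds named here.

Working notes on the series. In a functional assay on HT-29 cells (Homo sapiens) for inhibition, read by MTT assay, with a stated time of 2 days (on this read-out lower numbers stand for stronger inhibition and higher numbers for weaker inhibition), compound 1 `Nc1cccc(/C=C/c2ccccc2)c1` gives 12.9 ug/mL. Among the measured compounds shown here, compound 2 `COc1ccc(/C=C/c2cccc(O)c2)cc1` gives 22 ug/mL, which lies within the usual scatter of compound 1, the only other compound measured so far. Compound 3 `COc1ccc(/C=C/c2cccc(N)c2)cc1` has not yet been measured. It differs from compound 2 by amino in place of hydroxy on an aromatic carbon, with amino in place of hydroxy on an aromatic carbon, meta to a large group. For the measured compounds named here, no measured pair isolates this exchange, so its size in this assay cannot be read directly from the data. Going by the values given here, the only guide is compound 1, which also carries amino and gives 12.9 ug/mL, although its structure differs from that of compound 3 in other respects. The expected 1.6-fold lower number from compound 2 to compound 3 (0.20 log units; within the scatter) is a small move towards a lower number, not clearly beyond the scatter. Compound 3 is estimated at 14 ug/mL, with an expected range of 5 ug/mL to 35 ug/mL.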

Compound 3, half-maximal inhibitory concentration: 16.3 ug/mL
Compound 3: the middle estimate sits 1.2-fold (0.07 log units) below what was measured; the measured number falls inside the stated range.
By their numbers in this assay, from the lowest: compounds 1, 3 and 2 (each within the scatter of the next).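

In this assay, amino in place of hydroxy on an aromatic carbon, meta to a large group, now has a measured size: a 1.3-fold lower number from compound 2 to compound 3 (0.13 log units; within the scatter) stands as the step for this exchange, so this position does not separate the two groups on the methoxy-bearing core. Methoxy in place of hydrogen on an aromatic carbon gives a 1.3-fold higher number from compound 1 to compound 3 (0.10 log units; within the scatter) as its step, so with amino present, that exchange is not separated from the scatter either. No measured evidence bears on the reason for either step.

Each exchange is seen only once, on a single background, so neither can be taken as general. On these data alone, whether a carboxylic acid or an acetamide at the amino position, or ethoxy in place of methoxy, would move the number beyond the scatter remains open.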